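Phenethyl in place of 3-fluorophenyl on a sulfur

A few compounds are considered here, and "the series" means these few. Any claim that something is new, unique, unknown or untested is made for them only; others in the source may bear on it.

Compound 1 (`Nc1ccccc1NC(=O)c1ccc(CSc2cccc(F)c2)cc1`) gives 83% in a functional assay on SMMC-7721 cells (Homo sapiens) for inhibition, read by CCK-8 assay, with a stated time of 72 h, tested at 8 uM (on this read-out lower numbers stand for less inhibition of growth and higher numbers for more inhibition of growth at the one concentration tested), and compound 2 (`COc1ccc(SCc2ccc(C(=O)Nc3ccccc3N)cc2)cc1OC`) gives 78.9% in the same test. Among the measured compounds shown here, these two numbers lie within the scatter of each other, so compound 1 stands level with the only other measured compound.

Compound 3 (`Nc1ccccc1NC(=O)c1ccc(CSCCc2ccccc2)cc1`) has phenethyl in place of 3-fluorophenyl on a sulfur and otherwise matches compound 1. For the measured compounds named here, no measured pair shows a step for a change of this kind, so the expectation has little support. The value of compound 1 (83%) leaves little room for a rise. In this assay the expected result is a number 9 percentage points lower from compound 1 to compound 3 (within the scatter) (a slight fall in inhibition of growth, none beyond the scatter). The estimated value for compound 3 is 74% (expected range 52% to 88%).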

Compound 3, percent growth inhibition at one concentration: 77.9%
The estimate for compound 3 lay 3.9 percentage points below the measured number; low and high end bracket the measured number.
By their numbers in this assay, from the lowest: compounds 3, 2 and 1 (each within the scatter of the next).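

Among the compounds shown here, on the sulfur of the shared core, phenethyl in place of 3-fluorophenyl gives a number 5.1 percentage points lower from compound 1 to compound 3 (within the scatter) in this assay, the first one-place step. This position therefore accepts a phenyl ring carried on a chain as well as a ring bearing fluorine set directly on the sulfur, with compound 3 still inside the scatter of compound 1, although this single step changes the chain and removes the fluorine together, so neither can be read alone. Nothing in hand explains this result or ties it to any property of either group.

The compounds shown leave open how an unsubstituted phenyl, a benzyl group or a longer chain would read at this sulfur. Also open, as far as these compounds go, is whether an amine or a carboxylic acid at the end of such a chain would keep the inhibition of growth seen here.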